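Cyclobutyl carboxamide in place of hydroxycyclobutylmethyl on the core

The source may report more compounds than this note shows. Statements on the series, on what has been measured and on what is new or still open speak of the compounds shown alone.

Compound 1 `N#Cc1cnc(NCc2cnccc2C(F)(F)F)cc1NC[C@H]1C[C@H](O)C1` marks the weak end of the numbers shown. In an assay on isolated protein for inhibition of protein kinase C delta type (Homo sapiens), read by TR-FRET, with a stated time of 2 h (a lower number here means a stronger inhibitor, a higher number a weaker inhibitor), compound 1 gives > 10000 nM, which is a limit of the assay and not a number. Compound 2 `CC1(C)C[C@H](Nc2cc(NCc3cnccc3C(F)(F)F)ncc2C#N)CC(C)(C)[C@@H]1O` gives 700 nM in this assay, and compound 3 `CC1(C)C[C@H](Nc2cc(NCc3cnccc3C(F)(F)F)ncc2C#N)CC(C)(C)[C@H]1O` gives 500 nM. The step of a 1.4-fold lower number from compound 2 to compound 3 (0.15 log units; within the scatter) concerns only configuration, as the fact that compounds 2 and 3 differ only in the configuration as drawn shows. Compound 4 `CC1(C)[C@H](Nc2cc(NCc3cnccc3C(F)(F)F)ncc2C#N)C[C@H]1C(N)=O` arises from compound 1 by 3-carbamoyl-2,2-dimethylcyclobutyl in place of (3-hydroxycyclobutyl)methyl on a nitrogen on an aromatic ring. Within the data shown here, no measured step bears on this change; the only step known is the configurational one between compound 2 and compound 3, and the starting point is a limit (the limit of > 10000 nM in this assay, at which 1 of the 3 values shown sits), so the size of the step from compound 1 is not fixed. A value nearer compound 2 and compound 3 is expected for compound 4, at 2000 nM (400 nM to 10000 nM), a step of an at least 5.0-fold lower number from compound 1 to compound 4 (0.69 log units; beyond the scatter).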

Compound 4, half-maximal inhibitory concentration: 900 nM
Compound 4: the middle estimate sits 2.2-fold (0.35 log units) above what was measured; measured number inside the range.
By their numbers in this assay, from the lowest: compounds 3, 2 and 4 (each within the scatter of the next). At a limit, above all of these: compound 1.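

In this assay, 3-carbamoyl-2,2-dimethylcyclobutyl in place of (3-hydroxycyclobutyl)methyl on a nitrogen on an aromatic ring gives an at least 11-fold lower number from compound 1 to compound 4 (1.04 log units; beyond the scatter). On these data alone, the value of compound 1 is a limit of the assay and not a number, so the size of this step stays open: the limit of > 10000 nM in this assay, at which 1 of the 4 values shown sits. Compound 4 shows that a carboxamide-bearing group at this nitrogen also gives a measurable value, not only the hydroxyl-bearing groups of compound 2 and compound 3.

The compounds shown do not separate the contributions of the two methyl groups, the carboxamide and the loss of the methylene link. As far as these compounds go, whether a carboxylic acid or an amine in place of the carboxamide would hold this level also remains open.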